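The source may report more compounds than this note shows. Statements on the series, on what has been measured and on what is new or still open speak of the compounds shown alone.

Compound 1 `CC(C)c1c(C(=O)NCC2CCCCC2)nn(-c2ccc(F)cc2)c1OC[C@@H](O)C[C@@H](O)CC(=O)O`: 17 nM
Compound 2 `CC(C)c1c(C(=O)N2CCC[C@H](N3CCC4C=CC=CC4C3)C2)nn(-c2ccc(F)cc2)c1CC[C@@H](O)C[C@@H](O)CC(=O)O`: 10 nM

Both compounds were tested in an assay on microsomes from liver for inhibition of 3-hydroxy-3-methylglutaryl-coenzyme A reductase (Rattus norvegicus); on this read-out higher numbers stand for weaker inhibition and lower numbers for stronger inhibition. On these two numbers compound 1 holds the highest value, yet the gap to compound 2 is within the usual scatter of repeated measurements, so the two cannot be told apart on this read-out. For the measured compounds named here, the two compounds also differ in several places at once, so no single structural step between them can be read from their values.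

Compound 3 `Cc1ccccc1CNC(=O)c1nn(-c2ccc(F)cc2)c(OC[C@@H](O)C[C@@H](O)CC(=O)O)c1C(C)C` has not yet been measured in this assay. It differs from compound 1 in one place: 2-methylphenyl in place of cyclohexyl on a saturated chain carbon bound to an amide-type nitrogen. Going by the values given here, no measured pair shows what this kind of swap does, so the expectation rests on compound 1 alone. The expected outcome is a 1.5-fold higher number from compound 1 to compound 3 (0.17 log units; within the scatter), a shift no larger than the scatter allows in either direction. Compound 3 is therefore estimated at 25 nM, with a range from 8 nM to 80 nM.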

Compound 3, half-maximal inhibitory concentration: 17 nM
For compound 3 the middle estimate is 1.5-fold (0.17 log units) above the measured one; measured number inside the range.
By their numbers in this assay, from the lowest: compounds 2, 1 and 3 (each within the scatter of the next).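

In this assay, putting 2-methylphenyl in place of cyclohexyl on a saturated chain carbon bound to an amide-type nitrogen gives no change at the digits printed from compound 1 to compound 3 (within the scatter). For the compounds shown here, this is the first single-place comparison, and it shows that a six-membered aromatic ring carrying a methyl group can stand where a six-membered non-aromatic ring stood without a readable difference in this read-out. Nothing at hand explains why the two groups give matching numbers.

The compounds shown leave open whether the methyl group on the ring matters, since plain benzyl does not appear among them for comparison. They also leave open whether this position would accept a ring carrying an amine or a carboxylic acid, or a longer chain between the amide nitrogen and the ring.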